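Perfluorohexyl hydroxamate anilides: changing the anilide substituent

A few compounds are considered here, and "the series" means these few. Any claim that something is new, unique, unknown or untested is made for them only; others in the source may bear on it.

Measured so far:
- compound 1, `CC(=O)Nc1ccc(NC(=O)C(F)(F)C(F)(F)C(F)(F)C(F)(F)C(F)(F)C(F)(F)C(=O)NO)cc1`: 9200 nM
- compound 2, `O=C(NO)C(F)(F)C(F)(F)C(F)(F)C(F)(F)C(F)(F)C(F)(F)C(=O)Nc1ccc(I)cc1`: 4200 nM

In an assay on isolated protein for inhibition of protein deacetylase HDAC6 (Homo sapiens), read by fluorescence (on this read-out lower numbers stand for tighter binding and higher numbers for weaker binding), compound 1 gives 9200 nM and stands at the higher of the two numbers; the nearer and only other compound is compound 2, and the step of a 2.2-fold lower number from compound 1 to compound 2 (0.34 log units; beyond the scatter) is modest but beyond the scatter.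

Compound 3, `O=C(NO)C(F)(F)C(F)(F)C(F)(F)C(F)(F)C(F)(F)C(F)(F)C(=O)Nc1ccc(-c2cn(-c3ccccc3)nn2)cc1`, is not yet measured. Relative to compound 1 the change is 1-phenyl-1H-1,2,3-triazol-4-yl in place of acetamido on an aromatic carbon; the acetamido leaves and a 1-phenyl-1H-1,2,3-triazol-4-yl enters on an aromatic carbon, para to a large group, with the shared core otherwise unchanged.

Going by the values given here, only one measured step bears on this position: a 2.2-fold lower number from compound 1 to compound 2 (0.34 log units; beyond the scatter), where iodo in place of acetamido gave a lower number. Among the compounds with values here, the new group is larger and aromatic rather than a small amide, so no direct analogue exists; the one step available points to a modest lowering when the acetamido is removed, and a step of similar or somewhat greater size is expected here, with wide uncertainty.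

For compound 3 in this assay the estimate is 3000 nM, within 800 nM to 12000 nM, corresponding to an expected step of a 3.1-fold lower number from compound 1 to compound 3 (0.49 log units; beyond the scatter).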

Compound 3, dissociation constant: 8200 nM
Estimate against measurement, compound 3: 2.7-fold (0.44 log units) below, within the range that was stated.
By their numbers in this assay, from the lowest: compounds 2, 3 and 1 (each within the scatter of the next, the first and the last beyond it).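

Notes on the anilide substituent: in this assay, the 1-phenyl-1H-1,2,3-triazol-4-yl group, with its 11 heavy atoms and two aromatic rings, gives a 1.1-fold lower number from compound 1 to compound 3 (0.05 log units; within the scatter) when it replaces acetamido and a 2.0-fold higher number from compound 2 to compound 3 (0.29 log units; within the scatter) when it replaces iodo. Going by these compounds alone, the earlier pair covered only acetamido and iodo, so this is the first sign that a much larger substituent with two aromatic rings on this aromatic carbon, para to a large group, can leave the number within the scatter of both of those compounds. Compound 3 therefore does not extend the separation seen between compound 1 and compound 2, and no measurement to hand explains either the absence of a step here or the earlier step.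

From the compounds shown here alone, it remains open whether a small group of another kind on the same carbon, such as an amine or a carboxylic acid, would move the number beyond the scatter of these three compounds. Going by these compounds, a phenyl group attached directly to this carbon, or a longer chain in place of the perfluorohexyl chain, also remains untested against this shared core.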